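Fluoro in Place of Bromo on the Benzyl Arm

The compounds below may be only part of what the source reports. "The series", "measured", "known", "first", "only" and "open" are said of these compounds alone.

Compound 2 `O=C(/C=C/c1ccc(OCc2cn(Cc3ccccc3)nn2)cc1)c1ccc(Br)cc1` gives 22% in a functional assay on HepG2 cells (Homo sapiens) for inhibition, read by MTT assay, with a stated time of 48 h, tested at 10 uM (on this read-out lower numbers stand for less inhibition of growth and higher numbers for more inhibition of growth at the one concentration tested), and there stands level with compound 1 `C#CCOc1ccc(/C=C/C(=O)c2ccc(Br)cc2)cc1`, which gives 22%; the two share the lowest numbers of the three measured, while compound 3 `O=C(/C=C/c1ccc(OCc2cn(Cc3ccccc3Br)nn2)cc1)c1ccc(Br)cc1` gives 34%. For the measured compounds named here, the one relevant step is a number 12 percentage points higher from compound 2 to compound 3 (beyond the scatter). Compound 4 `O=C(/C=C/c1ccc(OCc2cn(Cc3ccccc3F)nn2)cc1)c1ccc(Br)cc1` differs from compound 2 by fluoro in place of hydrogen on an aromatic carbon, the same position that carries bromo in compound 3. Going by the values given here, with only one step on the bromo analogue to go by, and a fluorine entering in place of bromine, a smaller rise is expected than a number 12 percentage points higher from compound 2 to compound 3 (beyond the scatter), so the estimated step of a number 5 percentage points higher from compound 2 to compound 4 (within the scatter) may well stay within the scatter. Compound 4 is therefore expected at 27%, within 15% to 40%.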

Compound 4, percent growth inhibition at one concentration: 29%
Estimate against measurement, compound 4: 2 percentage points below; low and high end bracket the measured number.
By their numbers in this assay, from the lowest: compounds 1, 2, 4 and 3 (each within the scatter of the next, the first and the last beyond it).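

Fluoro in place of hydrogen gives a number 7 percentage points higher from compound 2 to compound 4 (within the scatter) in this assay and fluoro in place of bromo gives a number 5 percentage points lower from compound 3 to compound 4 (within the scatter) on the same read-out, so the 2-fluorobenzyl arm cannot be told apart from either the benzyl arm or the 2-bromobenzyl arm. At this position, then, the gain seen with bromo is neither confirmed nor ruled out for fluoro. Nothing available explains these numbers. Going by these compounds, whether a chloro, methoxy or amino group at this same place would separate clearly from compound 2 remains open.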